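A Coumarin Amide Study: Hydroxymethyl Replacing Piperidinylmethyl

The source may hold more compounds than are shown below. What is called first, only, known or untested is meant among the compounds shown, and "the series" means these compounds.

Compound 1 `O=C(Nc1ccccc1)c1cc2cc(CN3CCCCC3)ccc2oc1=O` was examined in an assay on isolated protein for inhibition of coagulation factor XII (Homo sapiens), read by HPLC, with stated times of 10 min and 30 min, tested at 50 uM (a higher number here means more inhibition at the concentration tested (going by the name of the read-out), a lower number less inhibition), where compound 1 gives 28%. Of the two numbers recorded, that of compound 1 is the lower; compound 2 `O=C(Nc1cc(Cl)ccc1O)c1cc2cc(Cl)cc(Br)c2oc1=O` gives 99% in this assay, a value that lies beyond the scatter above compound 1. The step from compound 1 to compound 3 `O=C(Nc1ccccc1)c1cc2cc(CO)ccc2oc1=O` is hydroxy in place of piperidin-1-yl on a saturated chain carbon bound to an aromatic carbon. Among the compounds with values here, no measured pair shows this change, so no step size beyond the scatter is expected in either direction in this assay. Compound 3 is therefore estimated at 25%, within 5% to 55%, a step of a number 3 percentage points lower from compound 1 to compound 3 (within the scatter).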

Compound 3, a percentage reported as inhibition, at one concentration (the size of the read-out at that concentration, not a potency): 14%
The estimate for compound 3 lay 11 percentage points above the measured number; measured number inside the range.
By their numbers in this assay, from the lowest: compound 3; then compound 1; then compound 2.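

Within the data shown here, the step of a number 14 percentage points lower from compound 1 to compound 3 (beyond the scatter) in this assay is the first reading of this change, and it shows that the number responds to the group carried on a saturated chain carbon bound to an aromatic carbon. Of this pair, the (piperidin-1-yl)methyl compound has the higher number. Nothing measured here explains the difference.

From the compounds shown here alone, whether a smaller amine such as dimethylamino, a carboxylic acid or a longer chain would raise or lower the number in this place remains open. So does whether hydroxymethyl would give a similar step on another amide.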